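The source may hold more compounds than are shown below. What is called first, only, known or untested is meant among the compounds shown, and "the series" means these compounds.

Measured in a functional assay on DLD-1 cells (Homo sapiens) for cytotoxicity, read by MTT assay, with a stated time of 72 h; on this read-out higher numbers stand for weaker inhibition and lower numbers for stronger inhibition:
- compound 1 `COc1cccc(/C=N/c2c(C)n(C)n(-c3ccccc3)c2=O)c1` gives 832000000 nM
- compound 2 `Cc1c(/N=C/c2ccc(Cl)cc2Cl)c(=O)n(-c2ccccc2)n1C` gives 126000000 nM

Compound 2 holds the lower of the two numbers. Going by the values given here, the single step measured so far, a 6.6-fold lower number from compound 1 to compound 2 (0.82 log units; beyond the scatter), changed only the aryl group on the carbon with a double bond to nitrogen.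

Compound 3 `Cc1c(/N=C/c2cccc(Cl)c2)c(=O)n(-c2ccccc2)n1C` differs from compound 2 by 3-chlorophenyl in place of 2,4-dichlorophenyl on a carbon with a double bond to nitrogen. Among the compounds with values here, that same position moved the number modestly in the one step known, so a modest shift is expected here too, most likely back toward the number of compound 1: a 2.4-fold higher number from compound 2 to compound 3 (0.38 log units; beyond the scatter). Compound 3 is therefore estimated at 300000000 nM, with a range of 100000000 nM to 900000000 nM in this assay.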

Compound 3, half-maximal inhibitory concentration: 724000000 nM
For compound 3 the middle estimate is 2.4-fold (0.38 log units) below the measured one; the range from low to high includes it.
By their numbers in this assay, from the lowest: compound 2; then compounds 3 and 1 (each within the scatter of the next).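

In this assay, 3-chlorophenyl in place of 2,4-dichlorophenyl on the carbon with a double bond to nitrogen gives a 5.7-fold higher number from compound 2 to compound 3 (0.76 log units; beyond the scatter), so this position responds to a change of one chlorine and the chlorine count or pattern matters, not the presence of chloro alone. Chloro in place of methoxy on the aromatic carbon gives a 1.1-fold lower number from compound 1 to compound 3 (0.06 log units; within the scatter), within the scatter, so of the three aryl groups only 2,4-dichlorophenyl stands apart. No measurement on hand gives a reason for this difference.

Open, on these data alone, is whether the same separation holds for other chloro patterns on this aryl group. Also open, as far as these compounds go, is how an aryl group carrying an amine or a carboxylic acid would read at this position.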